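Swapping Hydroxy for Bromo on the Aryl Ring

The source may hold more compounds than are shown below. What is called first, only, known or untested is meant among the compounds shown, and "the series" means these compounds.

Compound 1 `N#Cc1c(-c2ccccc2O)c(C#N)c(=O)n(/N=C/c2cn(-c3ccccc3)nc2-c2ccccc2)c1N` carries a 2-hydroxyphenyl group on the shared core. In an ADME assay on NIH3T3 cells (Mus musculus) for cytotoxicity, read by MTT assay (on this read-out lower numbers stand for stronger inhibition and higher numbers for weaker inhibition), compound 1 gives 162 ug/mL, the highest number of the three measured compounds and therefore the weakest inhibition of cell growth among them. Compound 2 `N#Cc1c(-c2ccc(Cl)cc2)c(C#N)c(=O)n(/N=C/c2cn(-c3ccccc3)nc2-c2ccccc2)c1N` gives 64 ug/mL and compound 3 `COc1ccc(-c2c(C#N)c(N)n(/N=C/c3cn(-c4ccccc4)nc3-c3ccccc3)c(=O)c2C#N)cc1` gives 50 ug/mL. The steps away from compound 1 read a 2.5-fold lower number from compound 1 to compound 2 (0.40 log units; beyond the scatter) and a 3.2-fold lower number from compound 1 to compound 3 (0.51 log units; beyond the scatter), while between the two other compounds the step is a 1.3-fold lower number from compound 2 to compound 3 (0.11 log units; within the scatter).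

Compound 4 `N#Cc1c(-c2ccccc2Br)c(C#N)c(=O)n(/N=C/c2cn(-c3ccccc3)nc2-c2ccccc2)c1N` differs from compound 1 by a single change: bromo in place of hydroxy on an aromatic carbon. For the measured compounds named here, no measured step changes this one place on its own; the two measured steps from compound 1 each remove the hydroxy and each lowered the number modestly. On that basis a modest lowering is expected for compound 4 as well, a 2.0-fold lower number from compound 1 to compound 4 (0.31 log units; beyond the scatter), though with real uncertainty. Compound 4 is therefore estimated at 80 ug/mL in this assay, within a range from 40 ug/mL to 160 ug/mL.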

Compound 4, half-maximal inhibitory concentration: 174 ug/mL
The estimate for compound 4 lay 2.2-fold (0.34 log units) below the measured number; the measured number lies above the stated range.
By their numbers in this assay, from the lowest: compounds 3 and 2 (each within the scatter of the next); then compounds 1 and 4 (each within the scatter of the next).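

Putting bromo in place of hydroxy gives a 1.1-fold higher number from compound 1 to compound 4 (0.03 log units; within the scatter) in this assay, so losing the hydroxy does not by itself lower the number, and the hydroxy alone does not set compound 1 apart from compounds 2 and 3. Instead, a 2.7-fold higher number from compound 2 to compound 4 (0.43 log units; beyond the scatter) and a 3.5-fold higher number from compound 3 to compound 4 (0.54 log units; beyond the scatter) suggest a split among these four compounds, with the 2-hydroxyphenyl and 2-bromophenyl compounds at higher numbers and the 4-chlorophenyl and 4-methoxyphenyl compounds at lower numbers. No measurement shown here explains this split.

Still open, going by these compounds, is whether the split follows the place on the ring or the group itself, since the steps from 4-chlorophenyl and 4-methoxyphenyl to 2-bromophenyl change both at once. Also open, on these data alone, is how an amine or a carboxylic acid would read in place of the hydroxy.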